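The source may hold more compounds than are shown below. What is called first, only, known or untested is meant among the compounds shown, and "the series" means these compounds.

Compound 1 `COc1ccc(Cn2c(=O)nc(NCCNC(=N)N)n(Cc3ccc(C)cc3)c2=O)cc1` sits in the upper part of a small set in a functional assay on the whole organism (strain C57Bl/6) for inhibition, with Mus musculus as the target, with a stated time of 180 min, at 48 degrees C (a lower number here means that less compound is needed, a higher number that more compound is needed for the effect), where compound 1 gives 0.0045 nM. Compound 3 `CCc1ccc(Cn2c(=O)nc(NCCNC(=N)N)n(Cc3ccc(OC)cc3)c2=O)cc1`, which carries an ethyl in place of the methyl on one of the benzyl groups, gives 0.0058 nM in this assay, a value that sits within the scatter of the value of compound 1. Within the data shown here, compound 2 `Cc1ccc(Cn2c(NCCNC(=N)N)nc(=O)n(Cc3ccc(C(F)(F)F)cc3)c2=O)cc1` gives 0.000033 nM, the lowest number of the three, reached by the single measured step of a 140-fold lower number from compound 1 to compound 2 (2.13 log units; beyond the scatter).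

Compound 4 `COc1ccc(Cn2c(=O)nc(NCCNC(=N)N)n(Cc3ccc(Cl)c(Cl)c3)c2=O)cc1` differs from compound 1 at the other benzyl group: 3,4-dichlorophenyl in place of 4-methylphenyl on a saturated chain carbon bound to an aromatic nitrogen. Among the measured compounds shown here, no measured step changes this group; the only measured step is the one from compound 1 to compound 2, which alters the other aromatic ring and is large. It shows that this assay can respond strongly to a change on a benzyl substituent, but it does not tell the direction for a change on the 4-methylphenyl side, and the values of compound 1 and compound 3 show that a small change there can leave the number within the scatter.

On balance, compound 4 is expected to show a modest step toward a lower number, a 5.0-fold lower number from compound 1 to compound 4 (0.70 log units; beyond the scatter), with wide uncertainty. The estimate for compound 4 in this assay is 0.0009 nM, with a range from 0.00005 nM to 0.015 nM.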

Compound 4, half-maximal effective concentration: 0.0045 nM
Compound 4: middle estimate off by 5.0-fold (0.70 log units), on the low side, and the stated range covers the measured number.
By their numbers in this assay, from the lowest: compound 2; then compounds 1, 4 and 3 (each within the scatter of the next).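

In this assay, among these compounds, replacing 4-methylbenzyl with 3,4-dichlorobenzyl gives no change at the digits printed from compound 1 to compound 4 (within the scatter), so at this position a substitution that exchanges the methyl for two ring chlorines leaves the number in place, a direction the earlier compounds could not supply. Among the compounds shown here, the same starting compound responds very differently when the other benzyl group is altered, as trifluoromethyl in place of methoxy gives a 140-fold lower number from compound 1 to compound 2 (2.13 log units; beyond the scatter), and the contrast places the only large measured step in this small set on the methoxy-bearing side rather than on the side changed here. No measurement offered here explains why the dichlorinated compound matches compound 1 or why the two sides differ.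

The compounds shown leave open whether the 3,4-dichlorophenyl group would also leave the number in place alongside the trifluoromethyl group of compound 2, where the other ring already gives a far lower number. They also leave open how this position would respond to a group of another kind on the ring, such as an amine or a carboxylic acid, or to a longer chain between the ring and the aromatic nitrogen.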